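A few compounds are considered here, and "the series" means these few. Any claim that something is new, unique, unknown or untested is made for them only; others in the source may bear on it.

Compound 1 `CS(=O)(=O)Nc1ccc2c(c1)S(=O)(=O)N=C(C1=C(O)[C@H]3CCC[C@H]3N(Cc3ccc(F)c(Cl)c3)C1=O)N2` — in an ADME assay on Huh-7 cells (Homo sapiens) for cytotoxicity, with a stated time of 72 h (a lower number here means that less compound is tolerated, a higher number that more compound is tolerated), compound 1 gives > 1000 nM, a limit of the assay.
Compound 2 `CS(=O)(=O)Nc1ccc2c(c1)S(=O)(=O)N=C(C1=C(O)[C@H]3CCC[C@H]3N(Cc3cccc(C(F)(F)F)c3)C1=O)N2` — in this assay compound 2 gives > 33000 nM, also a limit.

Both measured compounds therefore sit at limits rather than at numbers, and the step that the two limits leave unreadable from compound 1 to compound 2 cannot be sized. Compound 2 stands at the limit of > 33000 nM in this assay, at which 1 of the 2 values shown sits, the higher of the two limits, while compound 1 stands at the limit of > 1000 nM in this assay, at which 1 of the 2 values shown sits.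

Compound 3 `CS(=O)(=O)Nc1ccc2c(c1)S(=O)(=O)N=C(C1=C(O)[C@H]3CCC[C@H]3N(CC3CC3)C1=O)N2` has not yet been measured. It differs from compound 2 by cyclopropyl in place of 3-(trifluoromethyl)phenyl on a saturated chain carbon bound to an amide-type nitrogen in a ring. Going by the values given here, no measured step covers a change of this kind on the saturated chain carbon bound to the amide-type nitrogen, and the single step available is unreadable, so nothing indicates a step beyond the scatter in either direction.

Compound 3 is therefore expected to give 33000 nM in this assay, within 8000 nM to 120000 nM, which would mean an expected step of a number no higher from compound 2 to compound 3 (the limit leaves the size open).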

Compound 3, half-maximal cytotoxic concentration: > 33000 nM
Compound 3: a limit, no number; the forecaster's own chance of this, stated with the estimate: 70%; the middle value sits exactly at the limit.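

Going by these compounds alone, compound 1, compound 2 and compound 3 all sit at limits rather than at numbers, and no step among them can be read. The compounds shown leave open where each true value lies in this assay, and whether swapping the group on the saturated chain carbon changes it at all.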